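Swapping isopropyl for furan-2-yl in compound 2

A few compounds are considered here, and "the series" means these few. Any claim that something is new, unique, unknown or untested is made for them only; others in the source may bear on it.

Measured in a functional assay on A549 cells (Homo sapiens) for cytotoxicity, read by MTT assay, with a stated time of 72 h; a lower number here means a stronger inhibitor, a higher number a weaker inhibitor:
- compound 1 `CCCC[S+]([O-])CCCCN=C=S`: 9560 nM
- compound 2 `CC(C)C[S+]([O-])CCCCN=C=S`: 9090 nM

Among the measured compounds shown here, compound 2 stands level with the only other measured compound, and the single step, a 1.1-fold lower number from compound 1 to compound 2 (0.02 log units; within the scatter), stays within the scatter. Compound 3 `[O-][S+](CCCCN=C=S)Cc1ccco1` puts furan-2-yl in place of isopropyl on a saturated chain carbon bound to a sulfur. For the measured compounds named here, no measured compound carries a ring, so the data give no direction. Going by the values given here, with a 1.1-fold lower number from compound 1 to compound 2 (0.02 log units; within the scatter) as the only guide, no step beyond the scatter is expected in this assay. The expected change is a 1.1-fold lower number from compound 2 to compound 3 (0.06 log units; within the scatter). For compound 3 the estimated value is 8000 nM, with an expected range of 3500 nM to 16000 nM.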

Compound 3, half-maximal inhibitory concentration: 5640 nM
Compound 3: the middle estimate sits 1.4-fold (0.15 log units) above what was measured; the measured number falls inside the stated range.
By their numbers in this assay, from the lowest: compounds 3, 2 and 1 (each within the scatter of the next).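

In this assay, a ring can stand on a saturated chain carbon bound to a sulfur without moving the number beyond the scatter. Furan-2-yl in place of isopropyl gives a 1.6-fold lower number from compound 2 to compound 3 (0.21 log units; within the scatter), and furan-2-yl in place of propyl gives a 1.7-fold lower number from compound 1 to compound 3 (0.23 log units; within the scatter). No evidence is available on what lies behind these numbers. Still open, on these data alone, is whether an amine, a carboxylic acid or a phenyl ring at this place would shift the number beyond the scatter. A longer chain at this place also remains an open question.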